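A few compounds are considered here, and "the series" means these few. Any claim that something is new, unique, unknown or untested is made for them only; others in the source may bear on it.

Working notes on the series.

Compound 1 `Clc1ccc(-c2noc(-c3occc3Br)n2)cc1` and compound 2 `Clc1ccc(-c2noc(-c3occc3Cl)n2)cc1` share a core and differ only by chloro in place of bromo on an aromatic carbon. In a functional assay on DLD-1 cells (Homo sapiens) for inhibition, with a stated time of 48 h, at 37 degrees C (a higher number here means a weaker inhibitor of growth, a lower number a stronger inhibitor of growth), compound 1 gives 510 nM, and compound 2 gives 510 nM, so the step of no change at the digits printed from compound 1 to compound 2 (within the scatter) shows the exchange of the halogen on the furan ring leaving the growth inhibition where it was.

Compound 3 `Clc1ccc(-c2noc(-c3occc3Br)n2)nc1` carries the same bromo-substituted furan on a different core; the difference between the core of compound 3 and the core of compound 1 is not broken down here. In this assay compound 3 gives 430 nM, a number within the scatter of both compound 1 and compound 2.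

Compound 4 `Clc1ccc(-c2noc(-c3occc3Cl)n2)nc1` is not yet measured. It is related to compound 3 by chloro in place of bromo on an aromatic carbon, the same change, at the same place on the furan ring, as that between compound 1 and compound 2. Among the measured compounds shown here, since that earlier change produced no change at the digits printed from compound 1 to compound 2 (within the scatter), the step is expected to be about no change at the digits printed from compound 3 to compound 4 (within the scatter) in this assay, resting on the single earlier pair only. For compound 4 the expected value in this assay is 430 nM, estimated between 250 nM and 750 nM.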

Compound 4, concentration for 50% growth inhibition: 600 nM
Beside the measured number, compound 4's estimate is 1.4-fold (0.14 log units) below it; low and high end bracket the measured number.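

In this assay the exchange of 3-bromofuran-2-yl for 3-chlorofuran-2-yl gives a 1.4-fold higher number from compound 3 to compound 4 (0.14 log units; within the scatter), and the two cores agree on this change: the same change on two cores in this assay, no change at the digits printed (within the scatter) from compound 1 to compound 2 and a 1.4-fold higher number (0.14 log units; within the scatter) from compound 3 to compound 4, 1.4-fold (0.14 log units) apart, within the scatter of two such steps. For these two cores, then, the bromo to chloro exchange carries over in the sense that neither step leaves the scatter, so the halogen at this place can be taken as interchangeable in this read-out. It does not show that a change of real size would carry from one core to the other, since nothing moved on either core, and two pairs say nothing about a third core or about the reason for the agreement.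

The compounds shown leave open how a methyl, a methoxy or an amine at that place on the furan ring would read in this assay. They also leave open what a nitrile or a longer chain would do in place of the chloro that all four compounds share.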